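A few compounds are considered here, and "the series" means these few. Any claim that something is new, unique, unknown or untested is made for them only; others in the source may bear on it.

Measured compounds:
compound 1 `Cc1ccc(NC2=CC(=O)c3nc4n(c3C2=O)[C@H]2OC[C@@H](O)[C@H]2OC4)cc1C` — 2820 nM
compound 2 `CCOc1ccccc1NC1=CC(=O)c2c(nc3n2[C@H]2OC[C@@H](O)[C@H]2OC3)C1=O` — 4320 nM

In a functional assay on ECa-109 cells for inhibition, with ECa-109 cell line (Homo sapiens) as the target, read by sulforhodamine B assay (a higher number here means a weaker inhibitor, a lower number a stronger inhibitor), compound 1 gives 2820 nM, the lower of the two numbers, yet compound 2 at 4320 nM lies within the scatter of that figure, so the two cannot be told apart. The account follows the step from compound 1 to compound 3 `O=C1C=C(Nc2cccc(Cl)c2)C(=O)c2c1nc1n2[C@H]2OC[C@@H](O)[C@H]2OC1`, where the change is 3-chlorophenyl in place of 3,4-dimethylphenyl on an amine nitrogen. Among the measured compounds shown here, no step between measured compounds is available to guide this exchange of one aryl group for another on the amine nitrogen. The step of a 1.2-fold higher number from compound 1 to compound 3 (0.09 log units; within the scatter) is expected to be small, with no direction beyond the scatter. Compound 3 is therefore estimated at 3500 nM, within a range from 1200 nM to 10000 nM.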

Compound 3, half-maximal inhibitory concentration: 4690 nM
The estimate for compound 3 lay 1.3-fold (0.13 log units) below the measured number; the measured number falls inside the stated range.
By their numbers in this assay, from the lowest: compounds 1, 2 and 3 (each within the scatter of the next).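

Among the compounds shown here, the one step readable at this amine nitrogen, 3-chlorophenyl in place of 3,4-dimethylphenyl, gives a 1.7-fold higher number from compound 1 to compound 3 (0.22 log units; within the scatter) in this assay on the shared core. At this position, then, the two aryl groups cannot be told apart, and a single chlorine on the phenyl ring leaves the number as indistinguishable as the two methyl groups do. Nothing further is available to explain this result. The compounds shown leave open whether a pyridine ring, a carboxylic acid on the phenyl ring or a plain alkyl chain on this nitrogen would move the number beyond the scatter.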